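The compounds below may be only part of what the source reports. "The series", "measured", "known", "first", "only" and "open" are said of these compounds alone.

Compound 1 `O=C(Cn1cc(-c2ccc([N+](=O)[O-])cc2)nn1)Nc1nc2ccccc2s1`: 3280 nM
Compound 2 `COC(=O)c1ccc(-c2cn(CC(=O)Nc3nc4ccccc4s3)nn2)cc1`: limit only, see below

For the measured compounds named here, in a functional assay on BMDM cells (Mus musculus, strain C57BL/6) for inhibition, with a stated time of 2 days (on this read-out lower numbers stand for stronger inhibition and higher numbers for weaker inhibition), compound 1 gives 3280 nM, the only number in the set. Compound 2 is reported in this assay only as a limit, > 30000 nM (the limit of > 30000 nM in this assay, at which 1 of the 2 values shown sits). Going by the values given here, the one measured step, an at least 9.1-fold higher number from compound 1 to compound 2 (0.96 log units; beyond the scatter), alters the group on the aromatic carbon and leaves the amide nitrogen untouched.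

Compound 3 `Cc1csc(NC(=O)Cn2cc(-c3ccc([N+](=O)[O-])cc3)nn2)n1` changes that nitrogen instead: 4-methyl-1,3-thiazol-2-yl in place of 1,3-benzothiazol-2-yl on an amide-type nitrogen. Among the compounds with values here, no measured step bears on this change, so no direction is supported and a step beyond the scatter cannot be ruled out either way.

Compound 3 is expected to give about 5000 nM in this assay, within 1500 nM to 20000 nM. This estimate corresponds to an expected step of a 1.5-fold higher number from compound 1 to compound 3 (0.18 log units; within the scatter).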

Compound 3, half-maximal inhibitory concentration: 190 nM
Estimate against measurement, compound 3: 26-fold (1.42 log units) above, and the stated range ends above it.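

Changing the group on the amide-type nitrogen from 1,3-benzothiazol-2-yl to 4-methyl-1,3-thiazol-2-yl gives a 17-fold lower number from compound 1 to compound 3 (1.24 log units; beyond the scatter) in this assay, so the six-membered aromatic ring of carbon only is not required for inhibition here. The amide side of the core therefore moves the read-out as well, not only the group on the aromatic carbon. Nothing measured here accounts for this step.

Open, from the compounds shown here alone, is how much of the step rests on the methyl, which a plain 1,3-thiazol-2-yl or a 4-tert-butyl-1,3-thiazol-2-yl would test. Also open, going by these compounds, is whether the step carries over when methoxycarbonyl stands in place of nitro.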